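Dichlorobenzyl variant of the sulfonamide imide series

A few compounds are considered here, and "the series" means these few. Any claim that something is new, unique, unknown or untested is made for them only; others in the source may bear on it.

Compound 1 `Cc1ccc(S(=O)(=O)Nc2ccc3c(c2)C(=O)N(CCOc2ccc(O)cc2)C3=O)cc1` gives 47700 nM in an assay on isolated protein for inhibition of lysosomal alpha-glucosidase (Rattus norvegicus), read by colorimetric assay; on this read-out lower numbers stand for stronger inhibition and higher numbers for weaker inhibition. Compound 3 `O=C1c2ccccc2C(=O)N1CCNc1ccccc1` gives 184000 nM in this assay. Compound 2 `Cc1ccc(S(=O)(=O)Nc2ccc3c(c2)C(=O)N(Cc2ccccc2)C3=O)cc1` is recorded only as a limit of this assay, > 200000 nM, so for compound 2 only a bound and no number is known, at the limit of > 200000 nM in this assay, at which 1 of the 3 values shown sits. Among the measured compounds shown here, the single measured step, an at least 4.1-fold higher number from compound 1 to compound 2 (0.62 log units; beyond the scatter), concerns a different change and bears on the present one only loosely. Compound 4 `Cc1ccc(S(=O)(=O)Nc2ccc3c(c2)C(=O)N(Cc2ccc(Cl)c(Cl)c2)C3=O)cc1` differs from compound 2 by 3,4-dichlorophenyl in place of phenyl on a saturated chain carbon bound to an amide-type nitrogen in a ring. For the measured compounds named here, no measured step addresses chlorine on this ring, so no shift beyond the scatter is expected in either direction. Compound 4 is therefore estimated at 200000 nM, within 50000 nM to 600000 nM, which means an expected step of a number no higher from compound 2 to compound 4 (the limit leaves the size open).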

Compound 4, half-maximal inhibitory concentration: 122000 nM
Compound 4: the middle estimate sits 1.6-fold (0.21 log units) above what was measured; the range from low to high includes it.
By their numbers in this assay, from the lowest: compound 1; then compounds 4 and 3 (each within the scatter of the next). At a limit, above all of these: compound 2.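

Read in this assay the change to 3,4-dichlorophenyl on a saturated chain carbon bound to an amide-type nitrogen in a ring gives an at least 1.6-fold lower number from compound 2 to compound 4 (0.21 log units; that floor lies within the scatter) and so yields a measured number at this position without the (4-hydroxyphenoxy)methyl group. The true size of that step cannot be read because compound 2 stands only at a limit: the limit of > 200000 nM in this assay, at which 1 of the 4 values shown sits.
The 3,4-dichlorobenzyl group does not match the hydroxyphenoxy chain, with a 2.6-fold higher number from compound 1 to compound 4 (0.41 log units; beyond the scatter) as the printed gap.

Open, from the compounds shown here alone, is whether one chlorine alone, or a carboxylic acid in place of the 3,4-dichlorophenyl, would shift the number.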